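This account rests on a few compounds, and the source may have more. Where it says the series, first, only, none or still open, it means among the compounds named here.

Going by the values given here, compound 2 `Nc1ccn(CCC2(N)OC(=O)C(OCc3ccccc3)=C2OCc2ccccc2)c(=O)n1` is one of two compounds measured in a functional assay on SW-620 cells (Homo sapiens) for inhibition, read by MTT assay, with a stated time of 72 h; on this read-out higher numbers stand for weaker inhibition and lower numbers for stronger inhibition. In this assay compound 2 gives only a limit of the assay, > 100000 nM. Among the compounds with values here, its single measured neighbour, compound 1 `NC1(CCn2ncc(=O)[nH]c2=O)OC(=O)C(OCc2ccccc2)=C1OCc1ccccc1`, differs from it in one place. In this assay compound 1 also gives only a limit, > 100000 nM. The step that the two limits leave unreadable from compound 1 to compound 2 therefore cannot be sized from these two readings. Compound 3 `NC1(CCn2c(=O)[nH]c(=O)[nH]c2=O)OC(=O)C(OCc2ccccc2)=C1OCc1ccccc1` has not yet been measured; it differs from compound 2 by a group of 9 heavy atoms (3 carbon, 3 nitrogen, 3 oxygen; one six-membered aromatic ring with 3 hetero atoms) in place of a group of 8 heavy atoms (4 carbon, 3 nitrogen, 1 oxygen; one six-membered aromatic ring with 2 hetero atoms), on a saturated chain carbon, two bonds along the chain from a saturated ring carbon. Within the data shown here, no measured step speaks directly to this change, and the only evidence available is the limit of > 100000 nM in this assay, at which 2 of the 2 values shown sit, so no step beyond the scatter can be foreseen in either direction. Compound 3 is expected to sit near that same limit, at an estimated 150000 nM with a range from 50000 nM to 500000 nM. The step that the limit leaves unreadable from compound 2 to compound 3 is thus expected to be small, if any.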

Compound 3, half-maximal inhibitory concentration: > 100000 nM
Compound 3 was reported as a limit; the forecaster's own chance of this, stated with the estimate: 85%; the middle value is on the limit's open side.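

Compound 3, like compound 1 and compound 2, is reported in this assay only as a limit of the assay, so no step among these three compounds can be read. On these data alone, how strongly any of them inhibits, and whether swapping the ring group changes that, stays open.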